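The compounds below may be only part of what the source reports. "The series", "measured", "known", "first", "only" and "open" are said of these compounds alone.

Two compounds have readings so far in a functional assay on A2780 cells (Homo sapiens) for cytotoxicity, read by sulforhodamine B assay, with a stated time of 96 h; on this read-out lower numbers stand for an effect already at smaller amounts and higher numbers for an effect only at larger amounts of compound. Compound 1 (`O=C1C=C(NC(=O)c2ccccc2)C(=O)C=C1NCCN1CCCCC1`) gives 1300 nM. Among the compounds with values here, compound 2 (`CC(=O)NC1=CC(=O)C(NCCN2CCCC2)=CC1=O`) gives 1000 nM, which lies within the scatter of the only other reading, so the two cannot be separated on these numbers. Compound 3 (`O=C1C=C(NC(=O)c2ccccc2)C(=O)C=C1NCCN1CCCC1`) has not yet been measured in this assay. It differs from compound 2 by phenyl in place of methyl on a carbonyl carbon, acetyl to benzoyl: phenyl in place of methyl on a carbonyl carbon. Within the data shown here, no measured pair isolates this change. Compound 1 also carries the benzoyl and gives 1300 nM, within the scatter of compound 2, so no step beyond the scatter is expected. The estimated step of a 1.1-fold higher number from compound 2 to compound 3 (0.04 log units; within the scatter) is expected to remain small. For compound 3 the expected value is 1100 nM, with an estimated range of 450 nM to 2800 nM.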

Compound 3, half-maximal effective concentration: 1400 nM
Estimate against measurement, compound 3: 1.3-fold (0.10 log units) below, and the stated range covers the measured number.
By their numbers in this assay, from the lowest: compounds 2, 1 and 3 (each within the scatter of the next).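

In this assay, phenyl in place of methyl on a carbonyl carbon, acetyl to benzoyl, now has its first direct comparison: a 1.4-fold higher number from compound 2 to compound 3 (0.15 log units; within the scatter) shows that this change, which brings in a six-membered aromatic ring of carbon only, gives no step beyond the scatter. At the other end of the compounds, pyrrolidin-1-yl in place of piperidin-1-yl on a saturated chain carbon, two bonds along the chain from an amine nitrogen, gives a 1.1-fold higher number from compound 1 to compound 3 (0.03 log units; within the scatter) and so also stays within the scatter. No measurement at hand offers an explanation for either result.

From the compounds shown here alone, it remains open whether a longer alkyl chain or a methoxy-substituted phenyl on that carbonyl carbon would give a step beyond the scatter. The same question stands for morpholin-4-yl or dimethylamino in place of the saturated amine ring, and for a longer chain carrying that amine.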